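Dropping One Methoxy Group from Compound 1

This account rests on a few compounds, and the source may have more. Where it says the series, first, only, none or still open, it means among the compounds named here.

Compound 1 `COc1cc(CN(C(=O)Nc2ccc(C)cc2)n2cnnc2)cc(OC)c1OC` and compound 2 `CC1CCC(NC(=O)N(Cc2ccccn2)n2cnnc2)CC1` were examined in a functional assay on DU-145 cells (Homo sapiens) for cytotoxicity, read by MTT assay, with a stated time of 48 h; on this read-out higher numbers stand for weaker inhibition and lower numbers for stronger inhibition. Compound 1 gives 20800 nM, the highest of the two numbers shown, yet compound 2 gives 20100 nM, and the gap between them lies within the scatter, so the pair cannot be told apart. Compound 3 `COc1ccc(CN(C(=O)Nc2ccc(C)cc2)n2cnnc2)cc1OC` is the untested relative of compound 1, differing by hydrogen in place of methoxy on an aromatic carbon. Among the measured compounds shown here, with no measured step to lean on, a shift no larger than the scatter is expected in this assay, in either direction. Compound 3 is thus estimated at 20000 nM, with a range from 8000 nM to 50000 nM. For compound 3 the expected step is a 1.0-fold lower number from compound 1 to compound 3 (0.02 log units; within the scatter).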

Compound 3, half-maximal inhibitory concentration: 26300 nM
Beside the measured number, compound 3's estimate is 1.3-fold (0.12 log units) below it; the measured number falls inside the stated range.
By their numbers in this assay, from the lowest: compounds 2, 1 and 3 (each within the scatter of the next).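

Hydrogen in place of methoxy on this aromatic carbon, ortho to a methoxy group, gives a 1.3-fold higher number from compound 1 to compound 3 (0.10 log units; within the scatter) in this assay. Among the compounds shown here, this is the only measured step at this position, and it shows that the methoxy group here can go without a shift beyond the scatter. No outside measurement bears on this result, so it offers no explanation for it. On these data alone, whether another group at this place, such as an amine or a carboxylic acid, would move the number beyond the scatter stays open. So does the effect of removing the remaining methoxy groups.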